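The source may hold more compounds than are shown below. What is called first, only, known or untested is meant among the compounds shown, and "the series" means these compounds.

In a functional assay on HUVEC cells (Homo sapiens), read by scintillation counting and thymidine incorporation, with a stated time of 24 h (on this read-out higher numbers stand for weaker inhibition and lower numbers for stronger inhibition), compound 1 `CCC(C)n1ncn(-c2ccc(N3CCN(c4ccc(OC[C@@H]5COC(c6ccc(Cl)cc6Cl)O5)cc4)CC3)cc2)c1=O` gives 328 nM, compound 2 `CCC(C)n1ncn(-c2ccc(N3CCN(c4ccc(OC[C@@H]5CO[C@@](Cn6cnc(C)n6)(c6ccc(Cl)cc6Cl)O5)cc4)CC3)cc2)c1=O` gives 272 nM and compound 3 `CCC(C)n1ncn(-c2ccc(N3CCN(c4ccc(OC[C@@H]5CO[C@@](Cn6cnc(C(F)(F)F)n6)(c6ccc(Cl)cc6Cl)O5)cc4)CC3)cc2)c1=O` gives 270 nM. Compound 3 therefore stands level with the other two, its number lying within the scatter of both.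

The next compound, compound 4 `CCC(C)n1ncn(-c2ccc(N3CCN(c4ccc(OC[C@@H]5CO[C@@](Cn6c(C)cnc6C)(c6ccc(Cl)cc6Cl)O5)cc4)CC3)cc2)c1=O`, differs from compound 3 at one place: 2,5-dimethyl-1H-imidazol-1-yl in place of 3-(trifluoromethyl)-1H-1,2,4-triazol-1-yl on a saturated chain carbon bound to a saturated ring carbon. In plain words, 2,5-dimethyl-1H-imidazol-1-yl stands in place of 3-(trifluoromethyl)-1H-1,2,4-triazol-1-yl on a saturated chain carbon bound to a saturated ring carbon.

The closest measured step is a 1.0-fold lower number from compound 2 to compound 3 (0.00 log units; within the scatter), where trifluoromethyl replaces methyl on an aromatic carbon, and it stays within the scatter. Compound 1 carries no such group at that place, yet its 328 nM also lies within the scatter of compound 3. Among the compounds with values here, no measured compound carries the 2,5-dimethyl-1H-imidazol-1-yl group, so the new ring itself remains untested and the expectation is loose. In this assay, no change beyond the scatter is expected, and the estimated step is a 1.0-fold lower number from compound 3 to compound 4 (0.02 log units; within the scatter). Compound 4 is estimated at 260 nM, with an expected range from 110 nM to 600 nM.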

Compound 4, half-maximal inhibitory concentration: 765 nM
Beside the measured number, compound 4's estimate is 2.9-fold (0.47 log units) below it; measured number outside the range, above it.
By their numbers in this assay, from the lowest: compounds 3, 2 and 1 (each within the scatter of the next); then compound 4.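

In this assay, the place on a saturated chain carbon bound to a saturated ring carbon now responds to what it carries, with a 2.8-fold higher number from compound 3 to compound 4 (0.45 log units; beyond the scatter) and a 2.8-fold higher number from compound 2 to compound 4 (0.45 log units; beyond the scatter), both modest but beyond the scatter. The earlier compounds shown here showed no such response: exchanging methyl for trifluoromethyl on the triazole gave a 1.0-fold lower number from compound 2 to compound 3 (0.00 log units; within the scatter), which is within the scatter, whereas replacing the 1,2,4-triazol-1-yl ring with 2,5-dimethyl-1H-imidazol-1-yl weakens inhibition to the same extent from either triazole. Nothing at hand explains this shift in the read-out.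

The ring and its substituents change together in this step, and the compounds shown do not separate the move to an imidazole from the two methyl groups, a question that an unsubstituted 1H-imidazol-1-yl group would address. From the compounds shown here alone, it also remains open how this place would respond to a group outside the azoles, such as an open-chain amine or a carboxylic acid.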